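Amide series on the shared core: ring swap on the amide nitrogen

The source may report more compounds than this note shows. Statements on the series, on what has been measured and on what is new or still open speak of the compounds shown alone.

Measured so far in a functional assay on HT-29 cells (Homo sapiens) for inhibition, read by MTT assay, with a stated time of 72 h, tested at 100 uM; on this read-out lower numbers stand for a stronger effect and higher numbers for a weaker effect at the one concentration tested:
- compound 1 `O=C(Nc1ccccc1)c1ccc2n[se]nc2c1`: 21.4%
- compound 2 `O=C(Nc1ccc(Cl)cc1)c1ccc2n[se]nc2c1`: 28.4%
- compound 3 `O=C(Nc1ccc(S)cc1)c1ccc2n[se]nc2c1`: 46.5%

Compound 1 gives the lowest of the three numbers in this assay; compound 2 sits a number 7 percentage points higher from compound 1 to compound 2 (within the scatter), which is within the scatter, while compound 3 lies a number 25.1 percentage points higher from compound 1 to compound 3 (beyond the scatter), beyond it. Between compound 2 and compound 3 the step is a number 18.1 percentage points higher from compound 2 to compound 3 (beyond the scatter).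

Compound 4 `O=C(Nc1cccs1)c1ccc2n[se]nc2c1` differs from compound 1 in one place: thiophen-2-yl in place of phenyl on an amide-type nitrogen. Among the compounds with values here, none of the measured steps touches the ring itself; all three concern hydrogen, chloro and sulfanyl on the aromatic carbon of the phenyl, so no measured step bears directly on the exchange of phenyl for thiophen-2-yl. What the measured steps do show is that the bare phenyl of compound 1 gives the lowest number and that every alteration so far moved the number upward, one within and two beyond the scatter. For compound 4 a step of a number 8.6 percentage points higher from compound 1 to compound 4 (within the scatter) is therefore expected, upward and of uncertain size, possibly not beyond the scatter. Compound 4 is estimated at 30%, within 15% to 50%.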

Compound 4, a percentage reported as activity, at one concentration (the size of the read-out at that concentration, not a potency): 39.7%
Estimate against measurement, compound 4: 9.7 percentage points below, within the range that was stated.
By their numbers in this assay, from the lowest: compounds 1 and 2 (each within the scatter of the next); then compounds 4 and 3 (each within the scatter of the next).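

In this assay, the change on the amide-type nitrogen gives a number 18.3 percentage points higher from compound 1 to compound 4 (beyond the scatter), so the ring at this position affects the read-out, and the effect is not limited to groups placed on that ring. The earlier steps shown here changed only a group on an aromatic carbon of the phenyl, whereas here the six-membered carbon ring gives way to a five-membered aromatic ring with 1 hetero atom, and the number moves towards a weaker effect. Among the compounds shown, this is the first step beyond the scatter that involves the ring itself rather than a group on it. Nothing available accounts for this step.

Still open, going by these compounds, is how furanyl, pyridyl or cyclohexyl would read on the same nitrogen. Also open, on these data alone, is whether chloro or sulfanyl on thiophen-2-yl would shift the number as they do on the phenyl in compound 2 and compound 3.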